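The source may hold more compounds than are shown below. What is called first, only, known or untested is meant among the compounds shown, and "the series" means these compounds.

Measured in an ADME assay on microsomes from liver (Mus musculus) for metabolic stability, read by LC-MS, with a stated time of 30 min, tested at 1 uM; a higher number here means that more of the compound is left, a lower number that less of the compound is left:
- compound 1 `Cc1ccccc1S(=O)(=O)c1ccc(CNC(=O)c2cc3cnccc3[nH]2)cc1`: 15%
- compound 2 `O=C(NCc1ccc(S(=O)(=O)c2ccccc2)cc1)c1cc2ncccc2s1`: 1.6%
- compound 3 `O=C(NCc1ccc(S(=O)(=O)c2cccc(C(F)(F)F)c2)cc1)c1cc2cnccc2[nH]1`: 49%

Of these three, compound 2 stands lowest at 1.6%, beyond the scatter from both others. Compound 4 `O=C(NCc1ccc(S(=O)(=O)c2ccccc2)cc1)c1cn2ccnc2cn1` has not yet been measured in this assay. It differs from compound 2 only on the carbonyl carbon: a group of 9 heavy atoms (6 carbon, 3 nitrogen; one five-membered aromatic ring with 2 hetero atoms, one six-membered aromatic ring with 2 hetero atoms) in place of a group of 9 heavy atoms (7 carbon, 1 nitrogen, 1 sulfur; one five-membered aromatic ring with 1 hetero atom, one six-membered aromatic ring with 1 hetero atom), on a carbonyl carbon.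

Within the data shown here, no measured step covers a change at that place. Among the measured compounds shown here, the one single-place step available is a number 34 percentage points higher from compound 1 to compound 3 (beyond the scatter), which is large but lies on a sulfonyl sulfur. It bears only indirectly, showing that one change can move numbers in this assay far within this series. Compound 1 differs from compound 2 in more than one place, so compound 1 at 15% says only that it stands higher than compound 2.

With compound 2 at 1.6%, little room remains downward, so any clear move is expected to be upward. The estimated change, moderate and beyond the scatter, is a number 13.4 percentage points higher from compound 2 to compound 4 (beyond the scatter). It is expected to be smaller than the step on the sulfonyl sulfur, though with wide uncertainty. The expected value for compound 4 is 15%, with an estimated range of 4% to 40%.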

Compound 4, percent of the compound remaining: 13%
For compound 4 the middle estimate is 2 percentage points above the measured one, within the range that was stated.
By their numbers in this assay, from the lowest: compound 2; then compounds 4 and 1 (each within the scatter of the next); then compound 3.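

In this assay, the exchange on the carbonyl carbon gives a number 11.4 percentage points higher from compound 2 to compound 4 (beyond the scatter). Among these compounds, this is the first single-place reading at this position, and it shows that the group on the carbonyl carbon can shift the percent remaining on its own while the rest of the structure stays fixed, even though the shift is modest. The two groups have the same count of heavy atoms, and neither has a hydrogen-bond donor, so the step goes with a different set of ring hetero atoms and one more hydrogen-bond acceptor rather than with a larger group, though the compounds shown offer no measurement that explains it.

Still open, from the compounds shown here alone, is whether this exchange would give a step of similar size with the 3-(trifluoromethyl)phenyl on the sulfonyl sulfur, as in compound 3, since only the unsubstituted phenyl sulfonyl side has been read at this position. Also open, going by these compounds, is how a single ring such as pyridine, or an open-chain amine such as dimethylamine, on the carbonyl carbon would stand in this assay.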